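Swapping a Fluorophenyl for a Benzyl on a Thiourea Nitrogen

The compounds below may be only part of what the source reports. "The series", "measured", "known", "first", "only" and "open" are said of these compounds alone.

Measured compounds:
- compound 1, `Fc1cccc(NC(=S)N/N=C/c2ccc3ccccc3n2)c1`, 70100 nM
- compound 2, `Cc1csc2sc(/C=N/NC(N)=S)c(C)c12`, 1120 nM
- compound 3, `CN(C)C(=S)N/N=C/c1nc2ccccc2s1`, 2100 nM

The three measured compounds were tested in a functional assay on HeLa cells (Homo sapiens) for antiproliferative activity, read by sulforhodamine B assay, with a stated time of 72 h; on this read-out higher numbers stand for weaker inhibition and lower numbers for stronger inhibition. Compound 1 stands at the highest of the three numbers, so it is the weakest inhibitor of the set. Its nearest neighbour is compound 3, whose number is lower by a gap well beyond the usual scatter, and compound 2 lies lower still, also beyond the scatter. Compound 1 is thus clearly set apart from the other two.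

The unmeasured compound 4, `S=C(NCc1ccccc1)N/N=C/c1ccc2ccccc2n1`, keeps the core of compound 1 and changes one group on the thiourea part. The change is benzyl in place of 3-fluorophenyl on an amide-type nitrogen. Among the measured compounds shown here, no measured pair shows exactly this change, so its effect in this assay can only be guessed from the fact that compound 1 is the weakest of the set and that the other two, with smaller groups on that nitrogen, sit far lower.

Compound 4 is expected to give 30000 nM, within a range from 8000 nM to 100000 nM. This means an expected step of a 2.3-fold lower number from compound 1 to compound 4 (0.37 log units; beyond the scatter), a moderate move toward stronger inhibition, but still leaving compound 4 well above compounds 2 and 3.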

Compound 4, half-maximal inhibitory concentration: 62800 nM
The estimate for compound 4 lay 2.1-fold (0.32 log units) below the measured number, within the range that was stated.
By their numbers in this assay, from the lowest: compounds 2 and 3 (each within the scatter of the next); then compounds 4 and 1 (each within the scatter of the next).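

In this assay, among the compounds shown here, putting benzyl in place of 3-fluorophenyl on the amide-type nitrogen gives a 1.1-fold lower number from compound 1 to compound 4 (0.05 log units; within the scatter) and so offers the first direct reading of a change at this position, with the two groups indistinguishable on this read-out. On paper the exchange is more than a relabelling: the six-membered aromatic ring stays, while seven carbon atoms in benzyl replace the six carbon atoms and one fluorine of 3-fluorophenyl, yet the number stays within the scatter for this one pair on this one core. Nothing measured here explains why the two compounds read alike.

Still open, as far as these compounds go, is whether a group of a different kind on this nitrogen, such as a longer chain like phenethyl, an aminoethyl chain or a chain ending in a carboxylic acid, would shift the number beyond the scatter. Also open, from the compounds shown here alone, is how the fluorine and the extra carbon count separately, which a plain phenyl group or a fluorobenzyl group on the same nitrogen could begin to separate.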